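Thiazole alkyne series: replacing the methyl on the core

This account rests on a few compounds, and the source may have more. Where it says the series, first, only, none or still open, it means among the compounds named here.

Measured so far in a functional assay on CHO cells for agonist activity at metabotropic glutamate receptor 5 (Homo sapiens), read by inositol phosphate accumulation; on this read-out lower numbers stand for stronger inhibition and higher numbers for weaker inhibition:
- compound 1 `Cc1nc(C#Cc2cccc(F)c2)cs1`: 23 nM
- compound 2 `Cc1nc(C#Cc2cccc(C(N)=O)c2)cs1`: 1000 nM

Compound 1 stands lowest of the two numbers shown; the one step, a 43-fold higher number from compound 1 to compound 2 (1.64 log units; beyond the scatter), was large and sits on the phenyl ring, not on the core. Compound 3 `OCC#Cc1nc(C#Cc2cccc(F)c2)cs1` differs from compound 1 by 3-hydroxyprop-1-yn-1-yl in place of methyl on an aromatic carbon. Among the measured compounds shown here, no measured step touches this place, so the size of the change in this assay is open; a moderate shift is expected. Compound 3 is estimated at 100 nM (range 20 nM to 600 nM), that is a 4.3-fold higher number from compound 1 to compound 3 (0.64 log units; beyond the scatter).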

Compound 3, half-maximal inhibitory concentration: > 10000 nM
Compound 3: only a limit was reported; the forecaster's own chance of this, stated with the estimate: 5%; middle value at least 100-fold (2.00 log units) from the limit.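

In this assay, the place on the core that carries the methyl tolerates this change poorly: 3-hydroxyprop-1-yn-1-yl in place of methyl gives an at least 430-fold higher number from compound 1 to compound 3 (2.63 log units; beyond the scatter). Among the compounds shown here, the earlier step sat on the phenyl ring, so this is the first sign that the read-out also depends on this place on the core. Compound 3 carries a limit and not a number, so the step has only a floor: the limit of > 10000 nM in this assay, at which 1 of the 3 values shown sits.

From the compounds shown here alone, whether the triple bond, the hydroxy group or the chain length drives the loss stays open. An ethyl, a hydroxymethyl or a prop-1-yn-1-yl group at this place would help separate these.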